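Methyl on the sulfonamide nitrogen: cytotoxicity outlook

The source may hold more compounds than are shown below. What is called first, only, known or untested is meant among the compounds shown, and "the series" means these compounds.

Compound 1 `O=c1c(C2=CS(=O)(=O)c3cc(F)ccc3N2)c(O)c2cc(F)ccc2n1Cc1ccc(F)cc1` carries a fluoro group on the aromatic carbon that the later analogues vary. In an ADME assay on 2209-23 cells (Homo sapiens) for cytotoxicity, read by WST assay (a lower number here means that less compound is tolerated, a higher number that more compound is tolerated), compound 1 reaches only the assay limit of > 50000 nM. Compound 2 `NC(=O)COc1ccc2c(c1)S(=O)(=O)C=C(c1c(O)c3cc(F)ccc3n(Cc3ccc(F)cc3)c1=O)N2`, with carbamoylmethoxy on that carbon, likewise gives only the limit > 50000 nM in this assay. Compound 3 `CS(=O)(=O)Nc1ccc2c(c1)S(=O)(=O)C=C(c1c(O)c3cc(F)ccc3n(Cc3ccc(F)cc3)c1=O)N2`, with methanesulfonamido there, also stands at a limit, > 50000 nM in this assay. Hence a step that the two limits leave unreadable from compound 1 to compound 2, a step that the two limits leave unreadable from compound 1 to compound 3 and a step that the two limits leave unreadable from compound 2 to compound 3 cannot be sized; every value sits at the limit of > 50000 nM in this assay, at which 3 of the 3 values shown sit. Compound 4 `CN(c1ccc2c(c1)S(=O)(=O)C=C(c1c(O)c3cc(F)ccc3n(Cc3ccc(F)cc3)c1=O)N2)S(C)(=O)=O` differs from compound 3 by methyl in place of hydrogen on a sulfonamide nitrogen. Among the compounds with values here, no measured step bears on this change, and none of the measured steps is readable. The step of a number no higher from compound 3 to compound 4 (the limit leaves the size open) is expected to be of no readable size. Compound 4 is therefore expected to remain at the limit, with an estimate of 50000 nM between 25000 nM and 150000 nM in this assay.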

Compound 4, half-maximal cytotoxic concentration: > 50000 nM
Compound 4 was reported as a limit; the forecaster's own chance of this, stated with the estimate: 85%; the middle value lies on the limit itself.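

The steps linking compound 4 with compound 1, compound 2 and compound 3 cannot be read, as all four compounds stand at a limit: the limit of > 50000 nM in this assay, at which 4 of the 4 values shown sit.

The compounds shown leave open at what concentration any of them becomes cytotoxic, and whether any of these changes alters tolerance in this assay.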